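Chain-extended acid analogue of compound 2

The source may hold more compounds than are shown below. What is called first, only, known or untested is meant among the compounds shown, and "the series" means these compounds.

Measured so far:
compound 1 `NC(=O)c1nnn(Cc2cc(Cl)c(Cl)c(Cl)c2)c1N`: 12 nM
compound 2 `O=C(O)CCc1nc(-c2cn(Cc3cc(Br)c(Br)c(Br)c3)nn2)no1`: 552 nM

In an assay for inhibition of acyl-CoA desaturase 1 (Rattus norvegicus), using microsomes (on this read-out lower numbers stand for stronger inhibition and higher numbers for weaker inhibition), compound 2 gives 552 nM, the highest of the two numbers seen. In this assay compound 1 gives 12 nM, a markedly lower number; the two compounds differ in several places at once, so their gap cannot be pinned on any single change. Compound 3 `O=C(O)CCCCc1nc(-c2cn(Cc3cc(Br)c(Br)c(Br)c3)nn2)no1` differs from compound 2 in one place only: 2-carboxyethyl in place of carboxy on a saturated chain carbon, two bonds along the chain from an aromatic carbon. Nothing measured in the series tells how the length of this acid-bearing chain affects the read-out. With no such comparison to lean on, the step from compound 2 to compound 3 in this assay is expected to be small, in either direction, and probably not beyond the usual scatter. For compound 3 the expected value in this assay is therefore 500 nM, with a range of 150 nM to 1800 nM; this corresponds to an expected step of a 1.1-fold lower number from compound 2 to compound 3 (0.04 log units; within the scatter).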

Compound 3, half-maximal inhibitory concentration: 5250 nM
For compound 3 the middle estimate is 11-fold (1.02 log units) below the measured one; the whole stated range lies below it.
By their numbers in this assay, from the lowest: compound 1; then compound 2; then compound 3.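

In this assay, the position carrying the acid chain proves sensitive to chain length: replacing 2-carboxyethyl with 4-carboxybutyl, with the carboxy group retained, gives a 9.5-fold higher number from compound 2 to compound 3 (0.98 log units; beyond the scatter). Going by these compounds alone, this is the first comparison that differs in one place only, and it shows that the longer of these two acid chains is the weaker, a step beyond the scatter. No measurement shown here bears on the origin of this step.

Within the data shown here, with only two chain lengths compared, no trend can be drawn, and it remains open how carboxymethyl, 3-carboxypropyl or a longer chain such as 5-carboxypentyl would read. Also open, going by these compounds, is whether an amine or a methyl ester in place of the carboxy group would keep the read-out of compound 2 or compound 3.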